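Thiazole to thiophene exchange on the shared core

The compounds below may be only part of what the source reports. "The series", "measured", "known", "first", "only" and "open" are said of these compounds alone.

Compound 2 `CCOC(=O)c1cnc(NN2C(=O)C=C(C)C2=O)nc1-c1nccs1` gives in a functional assay on Jurkat cells (Homo sapiens) for inhibition (on this read-out lower numbers stand for stronger inhibition and higher numbers for weaker inhibition), 2200 nM. Compound 1 `CCOC(=O)c1cnc(NN2C(=O)C=C(C)C2=O)nc1-c1cccs1` differs by thiophen-2-yl in place of 1,3-thiazol-2-yl on an aromatic carbon, and in this assay compound 1 gives 140 nM, a step of a 16-fold lower number from compound 2 to compound 1 (1.20 log units; beyond the scatter). Compound 3 `CCOC(=O)c1cnc(N(C)N2C(=O)C=C(C)C2=O)nc1-c1nccs1` differs from compound 2 by methyl in place of hydrogen on a nitrogen on an aromatic ring; in this assay compound 3 gives 1700 nM, the step being a 1.3-fold lower number from compound 2 to compound 3 (0.11 log units; within the scatter). Compound 4 `CCOC(=O)c1cnc(N(C)N2C(=O)C=C(C)C2=O)nc1-c1cccs1` is not yet measured and differs from compound 3 by thiophen-2-yl in place of 1,3-thiazol-2-yl on an aromatic carbon. This is the same kind of change as that from compound 2 to compound 1; the surroundings differ only in that the position is described as meta to a large group in one case and meta to a group of 9 heavy atoms in the other. A step of about a 13-fold lower number from compound 3 to compound 4 (1.12 log units; beyond the scatter) is expected, resting on a 16-fold lower number from compound 2 to compound 1 (1.20 log units; beyond the scatter). For compound 4 the expected value in this assay is 130 nM, between 50 nM and 400 nM.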

Compound 4, half-maximal inhibitory concentration: 94 nM
Beside the measured number, compound 4's estimate is 1.4-fold (0.14 log units) above it; the range from low to high includes it.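

The exchange of 1,3-thiazol-2-yl for thiophen-2-yl carries over from one core to the other in this assay, giving an 18-fold lower number from compound 3 to compound 4 (1.26 log units; beyond the scatter), in line with the earlier step: the same change on two cores in this assay, a 16-fold lower number (1.20 log units; beyond the scatter) from compound 2 to compound 1 and an 18-fold lower number (1.26 log units; beyond the scatter) from compound 3 to compound 4, 1.2-fold (0.06 log units) apart, within the scatter of two such steps. Methyl in place of hydrogen on the nitrogen stays within the scatter with thiophen-2-yl present as well, giving a 1.5-fold lower number from compound 1 to compound 4 (0.17 log units; within the scatter): the same change on two cores in this assay, a 1.3-fold lower number (0.11 log units; within the scatter) from compound 2 to compound 3 and a 1.5-fold lower number (0.17 log units; within the scatter) from compound 1 to compound 4, 1.2-fold (0.06 log units) apart, within the scatter of two such steps. This rests on two cores that differ by that one methyl, so it shows that the two changes read independently here, but not that the exchange would carry over to cores changed elsewhere.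

Still open, from the compounds shown here alone, is whether a longer chain such as propyl on that nitrogen keeps this behaviour. Also open, going by these compounds, is whether the thiophen-2-yl gain survives when a carboxylic acid or an amide takes the place of the ethoxycarbonyl group.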